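Methoxy for Fluoro on a Shared Core: Expected Shift

The source may hold more compounds than are shown below. What is called first, only, known or untested is meant among the compounds shown, and "the series" means these compounds.

Measured so far:
compound 1 `O=C(O)CN1C(=O)/C(=C/c2nc3cc(F)ccc3n2Cc2ccccc2F)SC1=S` with 20400 nM
compound 2 `O=C(O)CN1C(=O)/C(=C/c2nc3ccc(F)cc3n2Cc2ccccc2F)SC1=S` with 22400 nM
compound 3 `COc1ccc2c(c1)nc(/C=C1\SC(=S)N(CC(=O)O)C1=O)n2Cc1ccccc1F` with 11500 nM

All three were tested in a functional assay on Raji cells (Homo sapiens) for cytotoxicity, read by MTT assay, with a stated time of 48 h; on this read-out higher numbers stand for weaker inhibition and lower numbers for stronger inhibition. Compound 1 and compound 3 differ by one change, (methoxy in place of fluoro on an aromatic carbon), and the step from one to the other was a 1.8-fold lower number from compound 1 to compound 3 (0.25 log units; within the scatter). Compound 2 has the same atoms as compound 1, joined differently; the difference between the two cores is not broken down here. Compound 2 and compound 1 give numbers within the scatter of each other, and the same holds for compound 2 against compound 3.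

Compound 4 `COc1ccc2nc(/C=C3\SC(=S)N(CC(=O)O)C3=O)n(Cc3ccccc3F)c2c1` is not yet measured. Among the compounds with values here, it differs from compound 2 by methoxy in place of fluoro on an aromatic carbon, the same change, at the same place in the same words, as the one made from compound 1 to compound 3. Within the data shown here, with only that one earlier example to go on, the expectation is a shift of about the same size. For compound 4 this means an expected step of a 1.8-fold lower number from compound 2 to compound 4 (0.25 log units; within the scatter). Compound 4 is therefore expected near 12500 nM, between roughly 6000 nM and 30000 nM, because the earlier instance of this change gave a 1.8-fold lower number from compound 1 to compound 3 (0.25 log units; within the scatter).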

Compound 4, half-maximal inhibitory concentration: 12400 nM
Beside the measured number, compound 4's estimate is 1.0-fold (0.00 log units) above it, within the range that was stated.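

Placing methoxy in place of fluoro on the second core gave a 1.8-fold lower number from compound 2 to compound 4 (0.26 log units; within the scatter) in this assay, and this step matches the earlier one: the same change on two cores in this assay, a 1.8-fold lower number (0.25 log units; within the scatter) from compound 1 to compound 3 and a 1.8-fold lower number (0.26 log units; within the scatter) from compound 2 to compound 4, 1.0-fold (0.01 log units) apart, within the scatter of two such steps

Within these four compounds, then, the change carried over from one core to the other with a step of the same size. That agreement does not show that the change itself has any real effect, since each step lies within the usual scatter of repeated measurements, so neither pair can be told apart on this read-out. Two pairs also make no general rule for other cores in the series.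

Only fluoro and methoxy are shown on this aromatic carbon, so it stays open whether an amine, a nitrile or a longer chain such as ethoxy would give a step beyond the scatter. The rest of the structure is the same throughout, which leaves open what an ester in place of the carboxylic acid would do.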